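The compounds below may be only part of what the source reports. "The series", "measured", "known", "first", "only" and "open" are said of these compounds alone.

The series shares a hydroxamic acid end and a piperidine-bearing middle, and was tested in an assay on isolated protein for inhibition of protein deacetylase HDAC6 (Homo sapiens), read by fluorescence, with a stated time of 1 h, tested at 100 nM; on this read-out lower numbers stand for less inhibition and higher numbers for more inhibition at the one concentration tested (going by the name of the read-out). Compound 1, `CCCN1CCC(c2noc(COc3ccc(/C=C/C(=O)NO)cc3)n2)CC1`, gives 69%. Compound 2, `C=CCN1CCC(c2noc(COc3ccc(/C=C/C(=O)NO)cc3)n2)CC1`, gives 66%. Compound 3, `CN(Cc1nc(C2CCN(Cc3ccccc3F)CC2)no1)c1ncc(C(=O)NO)cn1`, gives 44%, the lowest of the three numbers, and its distance to both others lies beyond the scatter.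

Compound 4, `CN(Cc1nc(C2CCN(Cc3ccc(C#N)cc3)CC2)no1)c1ncc(C(=O)NO)cn1`, differs from compound 3 in one place: 4-cyanophenyl in place of 2-fluorophenyl on a saturated chain carbon bound to an amine nitrogen in a ring. For the measured compounds named here, the only measured step, a number 3 percentage points lower from compound 1 to compound 2 (within the scatter), swaps small chains on the ring amine and stayed within the scatter; it says nothing about exchanging one substituted benzyl group for another, so no measured step bears on this change. With no guide, the expected step of a number 1 percentage points higher from compound 3 to compound 4 (within the scatter) is none beyond the scatter. Compound 4 is therefore estimated to give about 45% in this assay, with a range from 25% to 65%.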

Compound 4, a percentage reported as inhibition, at one concentration (the size of the read-out at that concentration, not a potency): 38%
Beside the measured number, compound 4's estimate is 7 percentage points above it; the range from low to high includes it.
By their numbers in this assay, from the lowest: compounds 4 and 3 (each within the scatter of the next); then compounds 2 and 1 (each within the scatter of the next).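

For the compounds shown here, this is the first measured exchange of one substituted benzyl group for another on the ring amine, and in this assay going from 2-fluorobenzyl to 4-cyanobenzyl gives a number 6 percentage points lower from compound 3 to compound 4 (within the scatter) on the shared core. At this position, this read-out therefore does not separate the two groups, even though the entering group carries a triple bond and a hydrogen-bond acceptor that the leaving group lacks. Nothing measured here bears on what lies behind this result.

Going by these compounds alone, with only one such exchange available, it remains open whether a plain benzyl group, or a benzyl group carrying an amine or a carboxylic acid, would also stay within the scatter of compound 3. As far as these compounds go, it also remains open how either benzyl group would read on the core of compound 1, where the ring amine carries small chains.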